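The source may report more compounds than this note shows. Statements on the series, on what has been measured and on what is new or still open speak of the compounds shown alone.

Of the compounds shown here, three have so far been measured in a functional assay on B16-F0 cells (Mus musculus) for inhibition, read by CCK-8 assay, with a stated time of 48 h; on this read-out higher numbers stand for weaker inhibition and lower numbers for stronger inhibition. Compound 3 `COc1cc(-c2ccnc3cc(-c4ccc5c(ccn5C)c4)nn23)cc(OC)c1OC` gives 48 nM in this assay, the lowest of the three numbers. Compound 1 `COc1cc(-c2ccnc3cc(-c4cn(CO)c5ccccc45)nn23)cc(OC)c1OC` gives 93 nM in this assay, and since this lies within the usual scatter of the number for compound 3, no order can be drawn between the two. Compound 2 `Cn1ccc2cc(-c3cc4nccc(-c5ccc(F)cc5)n4n3)ccc21` gives 4780 nM in this assay, a number far beyond the scatter from compound 3; compound 2 differs from the others in more than one place, so its value shows only that this combination sits well higher.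

Compound 4 `COc1ccc(-c2cc3nccc(-c4cc(OC)c(OC)c(OC)c4)n3n2)cc1F` differs from compound 3 in one place: 3-fluoro-4-methoxyphenyl in place of 1-methyl-1H-indol-5-yl on an aromatic carbon. The rest of compound 3 is kept. Because compound 1 gives 93 nM and compound 3 gives 48 nM while carrying different groups, the shared core seems to tolerate some change, yet a group of this kind has not been tried. A modest step from compound 3 to compound 4, a 3.1-fold higher number from compound 3 to compound 4 (0.49 log units; beyond the scatter), is expected, toward a higher number, near the edge of the scatter. Compound 4 is estimated at 150 nM, between 40 nM and 600 nM.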

Compound 4, half-maximal inhibitory concentration: 3950 nM
For compound 4 the middle estimate is 26-fold (1.42 log units) below the measured one; measured number above the stated range.
By their numbers in this assay, from the lowest: compounds 3 and 1 (each within the scatter of the next); then compounds 4 and 2 (each within the scatter of the next).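

In this assay, putting 3-fluoro-4-methoxyphenyl in place of 1-methyl-1H-indol-5-yl on this aromatic carbon gives an 82-fold higher number from compound 3 to compound 4 (1.92 log units; beyond the scatter), with the rest of compound 3 kept. Within the data shown here, this single change shows that the group at this position has a large bearing on the number, which the earlier compounds could not show because no pair among them differed in one place only. Nothing measured here explains the step.

The exchange replaces a fused pair of rings with one substituted six-membered ring, so the step cannot be assigned to the loss of the five-membered ring, the fluorine or the methoxy group alone. Also open, as far as these compounds go, is whether a plain phenyl, a 4-methoxyphenyl or a 1H-indol-5-yl with hydrogen on its nitrogen would stay near compound 3 or near compound 4.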